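Swapping pyridinyl for phenyl on an adenosine amide

This account rests on a few compounds, and the source may have more. Where it says the series, first, only, none or still open, it means among the compounds named here.

Of the compounds shown here, three built on a shared core have been measured in an assay on CHO cells for displacement of a labelled ligand from adenosine receptor A3 (Homo sapiens), read by scintillation counting, with a stated time of 60 min; a lower number here means a stronger inhibitor, a higher number a weaker inhibitor. Compound 1 `COc1ccc(-c2nc(NC(=O)c3ccncc3)c3nn(-c4ccccc4)cc3n2)cc1` gives 9.83 nM in this assay, the lowest of the three numbers. Compound 2 `COc1ccc(-n2cc3nc(-c4cccs4)nc(N)c3n2)cc1` gives 78 nM in this assay, a higher number than compound 1 by a gap beyond the scatter. Compound 3 `O=c1[nH]c(-c2cccs2)nc2cn(-c3ccccc3)nc12` gives 413 nM in this assay, the highest of the three and the furthest from compound 1. None of these three pairs differs in a single place, so no gap among them can be tied to one change.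

Compound 4 `COc1ccc(-c2nc(NC(=O)c3ccccc3)c3nn(-c4ccccc4)cc3n2)cc1` differs from compound 1 in one place: phenyl in place of pyridin-4-yl on a carbonyl carbon. The single acceptor counted in the leaving group is lost; everything else in compound 1 is kept. Among the compounds with values here, no measured pair shows this exchange, so there is no step to lean on. Because compound 1 gives 9.83 nM in this assay, compound 4 is expected to give 8 nM, with a range from 2.5 nM to 30 nM. The expected change of a 1.2-fold lower number from compound 1 to compound 4 (0.09 log units; within the scatter) is estimated to stay within the scatter, in neither direction beyond it.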

Compound 4, inhibition constant: 6.42 nM
Beside the measured number, compound 4's estimate is 1.2-fold (0.10 log units) above it, and the stated range covers the measured number.
By their numbers in this assay, from the lowest: compounds 4 and 1 (each within the scatter of the next); then compound 2; then compound 3.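

Exchanging pyridin-4-yl for phenyl on a carbonyl carbon gives a 1.5-fold lower number from compound 1 to compound 4 (0.19 log units; within the scatter) in this assay, and this is the first step among the compounds shown that can be tied to one change. It shows that, at this place on the shared core, the nitrogen of the pyridin-4-yl ring and the hydrogen-bond acceptor counted with it can be replaced by the all-carbon phenyl ring without a shift that stands out from repeat measurements, so compound 1 and compound 4 read as level. No separate measurement that could account for this result is at hand.

What the compounds shown leave open is how much else this place accepts, since the single pair covers only two six-membered aromatic rings on the carbonyl carbon, and a pyridin-3-yl ring, a saturated cyclohexyl ring, a methyl group, a longer alkyl chain or a phenyl ring carrying an amine or a carboxylic acid could each read differently. Also open, as far as these compounds go, is whether the same exchange would stay within the scatter with other groups elsewhere on the shared core.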